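Acetyl series near the limit: the step to compound 4

A few compounds are considered here, and "the series" means these few. Any claim that something is new, unique, unknown or untested is made for them only; others in the source may bear on it.

Measured so far in a functional assay on MCF7 cells (Homo sapiens) for cytotoxicity, read by MTT assay, with a stated time of 48 h (on this read-out lower numbers stand for stronger inhibition and higher numbers for weaker inhibition), are three compounds:
- compound 1 `COc1ccc(-c2c[nH]c(=O)n2-c2cc(OC)c(OC)c(OC)c2)cc1N` gives > 50000 nM as a limit
- compound 2 `COc1ccc(-c2cn(C(C)=O)c(=O)n2-c2cc(OC)c(OC)c(OC)c2)cc1` gives > 50000 nM as a limit
- compound 3 `COc1cc(-n2c(-c3ccc(F)cc3F)cn(C(C)=O)c2=O)cc(OC)c1OC` gives 49300 nM as a number

Among the measured compounds shown here, compound 3 gives 49300 nM, the only number of the set. The other two values are limits. Compound 4 `COc1ccc(-c2cn(C(C)=O)c(=O)n2-c2cc(OC)c(OC)c(OC)c2)cc1N` is not yet measured. The change is 3-amino-4-methoxyphenyl in place of 2,4-difluorophenyl on an aromatic carbon and puts 3-amino-4-methoxyphenyl in place of 2,4-difluorophenyl on an aromatic carbon of the five-membered aromatic ring with 2 nitrogen.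

For the measured compounds named here, the one measured step at this place is an at least 1.0-fold lower number from compound 2 to compound 3 (0.00 log units; that floor lies within the scatter) and it stays within the scatter. Compound 1 carries the 3-amino-4-methoxyphenyl group without the acetyl group, and its > 50000 nM is a limit. Going by the values given here, no measured step tests the 3-amino-4-methoxyphenyl group with the acetyl group in place, so the central expectation in this assay is no change beyond the scatter, although a move toward lower numbers stays open. The expected size is a 1.6-fold lower number from compound 3 to compound 4 (0.22 log units; within the scatter) as an estimate with wide uncertainty. Compound 4 is estimated at 30000 nM with an expected range from 4000 nM to 50000 nM in this read-out.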

Compound 4, half-maximal inhibitory concentration: 43400 nM
Compound 4: the middle estimate sits 1.4-fold (0.16 log units) below what was measured; the measured number falls inside the stated range.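

In this assay, among the compounds shown here, the exchange of 2,4-difluorophenyl for 3-amino-4-methoxyphenyl on the aromatic carbon next to the ring nitrogen gives a 1.1-fold lower number from compound 3 to compound 4 (0.06 log units; within the scatter), the first step at this position with a number at both ends. With the acetyl group in place, the two groups therefore cannot be told apart in this assay, even though the hydrogen-bond donor and acceptors counted for the entering group are absent from the leaving one. The amino group in place of hydrogen gives an at least 1.1-fold lower number from compound 2 to compound 4 (0.06 log units; that floor lies within the scatter), and the acetyl group in place of hydrogen gives an at least 1.1-fold lower number from compound 1 to compound 4 (0.06 log units; that floor lies within the scatter), but both steps are floors only, because compound 1 and compound 2 each stand at a limit: the limit of > 50000 nM in this assay, at which 2 of the 4 values shown sit.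

As far as these compounds go, the true size of the amino and acetyl steps stays open, as does whether any group at this position can move the number beyond the scatter. Also open, from the compounds shown here alone, is whether a carboxylic acid on the phenyl group, or a longer chain in place of the acetyl group, would give a number clearly lower than those of compound 3 and compound 4.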